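The compounds below may be only part of what the source reports. "The series", "measured", "known", "first", "only" and "open" are said of these compounds alone.

In a functional assay on U-266 cells (Homo sapiens) for cytotoxicity, with a stated time of 72 h (on this read-out higher numbers stand for an effect only at larger amounts of compound and lower numbers for an effect already at smaller amounts), compound 1 `CC(C)=CCC/C(C)=C/Cc1c(O)cc2c(c1O)C(=O)C[C@@H](c1cc(O)cc(O)c1)O2` gives 1900 nM and compound 2 `CC(C)=CCC/C(C)=C/Cc1c(O)cc2c(c1O)C(=O)C[C@@H](c1ccc(O)c(O)c1)O2` gives 2400 nM. Among the compounds with values here, these two numbers lie within the scatter of each other, so compound 2 stands level with the only other measured compound. Compound 3 `COc1cc([C@@H]2CC(=O)c3c(cc(O)c(C/C=C(\C)CCC=C(C)C)c3O)O2)cc(O)c1O` carries methoxy in place of hydrogen on an aromatic carbon of compound 2 (methoxy in place of hydrogen on an aromatic carbon), turning 3,4-dihydroxyphenyl into 3,4-dihydroxy-5-methoxyphenyl. Within the data shown here, no measured step adds a methoxy, so the data offer no direct precedent. Among the measured compounds shown here, the one step that bears on this phenyl, the exchange of 3,5-dihydroxyphenyl for 3,4-dihydroxyphenyl, is a 1.3-fold higher number from compound 1 to compound 2 (0.10 log units; within the scatter). It gives only weak guidance, but it offers no reason to expect a large shift, and no direction can be drawn from it. The estimated step in this assay, no larger than the scatter, is a 1.0-fold higher number from compound 2 to compound 3 (0.02 log units; within the scatter). The expected value for compound 3 is 2500 nM, with an estimated range from 1000 nM to 6000 nM.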

Compound 3, half-maximal effective concentration: 5500 nM
Estimate against measurement, compound 3: 2.2-fold (0.34 log units) below; low and high end bracket the measured number.
By their numbers in this assay, from the lowest: compounds 1 and 2 (each within the scatter of the next); then compound 3.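

In this assay, within the data shown here, methoxy in place of hydrogen on the aromatic carbon is the first change at this phenyl to go beyond the scatter (a 2.3-fold higher number from compound 2 to compound 3 (0.36 log units; beyond the scatter)), a modest step. The exchange of 3,5-dihydroxyphenyl for 3,4-dihydroxy-5-methoxyphenyl points the same way (a 2.9-fold higher number from compound 1 to compound 3 (0.46 log units; beyond the scatter)), whereas moving a hydroxy group alone had stayed within the scatter, so this phenyl does respond to substitution, here towards a higher number. Nothing available ties this shift to any measured property of the compounds.

The compounds shown leave open whether the higher number belongs to methoxy in particular or to any group on that aromatic carbon, as a third hydroxy, a chlorine or a longer ethoxy there would show. They also leave open how an amine at that carbon would behave.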